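A cyclopropyl group on the amide-type nitrogen of compound 1

A few compounds are considered here, and "the series" means these few. Any claim that something is new, unique, unknown or untested is made for them only; others in the source may bear on it.

In a functional assay on MCF7 cells (Homo sapiens) for antiproliferative activity, read by MTT assay, with a stated time of 72 h (on this read-out higher numbers stand for weaker inhibition and lower numbers for stronger inhibition), compound 1 `COc1ncc(-c2ccc3c(c2)NC(=O)CO3)cc1NS(=O)(=O)c1ccc(F)cc1` gives 32300 nM and is the only one of the three measured compounds to return a number. Compound 2 `O=C1COc2ccc(-c3cnc(Cl)c(NS(=O)(=O)c4ccc(F)cc4)c3)cc2N1` gives > 40000 nM as a limit of the assay. Compound 3 `COc1cccc(N2C(=O)COc3ccc(-c4ccc(O)cc4)cc32)c1` gives > 40000 nM as a limit too. Compound 1 therefore has no second number to be ranked against, and its own value lies close to the limit of > 40000 nM in this assay, at which 2 of the 3 values shown sit, in the same read-out.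

Compound 4 `COc1ncc(-c2ccc3c(c2)N(C2CC2)C(=O)CO3)cc1NS(=O)(=O)c1ccc(F)cc1` differs from compound 1 at one place, with cyclopropyl in place of hydrogen on an amide-type nitrogen in a ring sums up that change.

Among the measured compounds shown here, the one measured step, an at least 1.2-fold higher number from compound 1 to compound 2 (0.09 log units; that floor lies within the scatter), lies elsewhere, with chloro in place of methoxy on an aromatic carbon, and its floor stays within the scatter. For the measured compounds named here, no measured step touches the amide-type nitrogen, so the data offer neither a size nor a direction for this change. No step beyond the scatter is therefore expected in this assay, and a report as a limit alone remains possible.

The expected move is a 1.3-fold lower number from compound 1 to compound 4 (0.11 log units; within the scatter), which stays within the scatter. For compound 4 the estimated value is 25000 nM, with an expected range from 6000 nM to 40000 nM.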

Compound 4, half-maximal inhibitory concentration: 35200 nM
Compound 4: the middle estimate sits 1.4-fold (0.15 log units) below what was measured, and the stated range covers the measured number.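

Among the compounds shown here, the first measured step at the amide-type nitrogen in a ring is now available: in this assay, cyclopropyl in place of hydrogen at this position gives a 1.1-fold higher number from compound 1 to compound 4 (0.04 log units; within the scatter). The position therefore carries a cyclopropyl group with no step beyond the scatter, and the read-out remains a number and does not become a limit, so compound 4 joins compound 1 as a second compound with a measured value. Even so, the two compounds read alike only in a part of the range with little room left, and a group that made no difference here might not behave the same way on a compound with a much lower number: the limit of > 40000 nM in this assay, at which 2 of the 4 values shown sit.

Going by these compounds, whether a different group on this nitrogen, such as a methyl, a longer alkyl chain, or a chain ending in an amine or a carboxylic acid, would produce a step beyond the scatter remains open. On these data alone, it is also open whether cyclopropyl would read the same with a change elsewhere on the shared core, such as the chloro group of compound 2 or a different sulfonamide substituent.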